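The compounds below may be only part of what the source reports. "The series", "measured", "known", "first", "only" and "open" are said of these compounds alone.

Measured compounds:

Compound 1, `COc1ccc(C(C)=O)cc1CSc1nc2cc(NC(=O)C3CC3)ccc2n1C(C)C`: > 10000 nM
Compound 2, `CCCn1c(SCc2cc([N+](=O)[O-])ccc2OC)nc2cc(NC(=O)NC(C)(C)C)cc(C(=O)OC)c21`: 280 nM
Compound 3, `CCCn1c(SCc2cc([N+](=O)[O-])ccc2OC)nc2cc(NC(=O)NC(C)(C)C)cc(C(=O)N(C)C)c21`: 200 nM

In an assay on isolated protein for inhibition of Gonadotropin-releasing hormone receptor (Rattus norvegicus) (a lower number here means a stronger inhibitor, a higher number a weaker inhibitor), compound 1 reports only a limit, (the limit of > 10000 nM in this assay, at which 1 of the 3 values shown sits), and no number. Compound 2 and compound 3 give the two numbers of the set, and they sit within the scatter of each other: the step of a 1.4-fold lower number from compound 2 to compound 3 (0.15 log units; within the scatter) is small, so neither is set apart from the other.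

Compound 4, `CCCn1c(SCc2cc([N+](=O)[O-])ccc2OC)nc2cc(NC(=O)NC(C)(C)C)cc(C(=O)NC(C)(C)C)c21`, differs from compound 3 by (tert-butyl)amino in place of dimethylamino on a carbonyl carbon. Going by the values given here, only one measured step touches the same place, the change from methoxy to dimethylamino on that carbonyl carbon, a 1.4-fold lower number from compound 2 to compound 3 (0.15 log units; within the scatter), and it stayed within the scatter. Nothing measured here shows a change at this carbonyl shifting the number beyond the scatter, so for compound 4 a step of a 1.1-fold higher number from compound 3 to compound 4 (0.04 log units; within the scatter) is expected, with no movement beyond the scatter. The estimate for compound 4 in this assay is 220 nM, within 80 nM to 600 nM.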

Compound 4, half-maximal inhibitory concentration: 490 nM
Estimate against measurement, compound 4: 2.2-fold (0.35 log units) below, within the range that was stated.
By their numbers in this assay, from the lowest: compounds 3, 2 and 4 (each within the scatter of the next, the first and the last beyond it). At a limit, above all of these: compound 1.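

In this assay, going by these compounds alone, a change on this carbonyl carbon had so far given only a step within the scatter, whereas the exchange of dimethylamino for (tert-butyl)amino gives a 2.5-fold higher number from compound 3 to compound 4 (0.39 log units; beyond the scatter) and so moves the number beyond the scatter, though modestly. Within the data shown here, the same group entering in place of methoxy gives a 1.8-fold higher number from compound 2 to compound 4 (0.24 log units; within the scatter) and stays within the scatter, so the position shows a measurable response for only one of the two exchanges. Nothing given here accounts for that step.

As far as these compounds go, it remains open whether the step follows the amide hydrogen that (tert-butyl)amino brings or the larger group as a whole, and methylamino or a plain amino group on the same carbonyl carbon would separate the two. From the compounds shown here alone, how a carboxylic acid at this place would compare also remains open.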